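Swapping ethoxycarbonyl for methoxycarbonyl: a small step

The source may hold more compounds than are shown below. What is called first, only, known or untested is meant among the compounds shown, and "the series" means these compounds.

Measured so far in a functional assay on MDA-MB-231 cells (Homo sapiens) for inhibition, read by sulforhodamine B assay, with a stated time of 72 h; on this read-out higher numbers stand for weaker inhibition of growth and lower numbers for stronger inhibition of growth:
- Compound 1 `CCOC(=O)/C=C/c1ccncc1-c1ccc2ccccc2c1`: 8090 nM.
- Compound 2 `O=C(/C=C/c1ccncc1-c1ccc2cc[nH]c2c1)N1CCOCC1`: > 10000 nM, a limit of the assay and not a number.
- Compound 3 `CCOC(=O)/C=C/c1ccncc1-c1ccc2c(ccn2C)c1`: 10200 nM.

Only two of these three results are true numbers, and they lie within the usual scatter of repeated measurements. Compound 1 at 8090 nM therefore cannot be told apart from compound 3 at 10200 nM.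

Compound 4 `COC(=O)/C=C/c1ccncc1-c1ccc2ccccc2c1` keeps the core of compound 1 and differs from it in one place: hydrogen in place of methyl on a saturated chain carbon bound to an oxygen next to a carbonyl group. Hydrogen stands in place of methyl on a saturated chain carbon bound to an oxygen next to a carbonyl group, so ethoxycarbonyl becomes methoxycarbonyl. This removes a single carbon from the molecule.

For the measured compounds named here, no pair of measured compounds shows this change on its own, so the expectation has to start from compound 1 at 8090 nM. With so small a change, no step beyond the scatter is expected in this assay, in either direction. The estimated step of a 1.0-fold lower number from compound 1 to compound 4 (0.00 log units; within the scatter) reflects this. For compound 4 the expected value is 8000 nM, with an estimated range from 3500 nM to 16000 nM.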

Compound 4, concentration for 50% growth inhibition: 4710 nM
Beside the measured number, compound 4's estimate is 1.7-fold (0.23 log units) above it; the measured number falls inside the stated range.
By their numbers in this assay, from the lowest: compounds 4, 1 and 3 (each within the scatter of the next, the first and the last beyond it).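

For the compounds shown here, this is the first reading of one single change. In this assay, going from ethoxycarbonyl to methoxycarbonyl gives a 1.7-fold lower number from compound 1 to compound 4 (0.23 log units; within the scatter), so removing this one carbon produces no difference that can be told apart from the ordinary variation between repeated measurements, and the chain end at this place need not be ethyl for compound 4 to give a value in the same range as compound 1. The earlier compounds could not show this, since no two of them differed in only one place, and compound 2 gives only a limit of the assay and not a number: the limit of > 10000 nM in this assay, at which 1 of the 4 values shown sits.

Going by these compounds, this one pair covers only a very small change, so it remains open whether a longer chain such as butyl, or a carboxylic acid in place of the methoxycarbonyl group, would give a step beyond the scatter. On these data alone, it also remains open whether the same swap from ethoxycarbonyl to methoxycarbonyl would give a similar result on the core of compound 3.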